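A Second Chloro Added to Compound 2

The source may report more compounds than this note shows. Statements on the series, on what has been measured and on what is new or still open speak of the compounds shown alone.

Compound 1 `O=c1c(C2N=C(c3ccccc3)SS2)coc2ccccc12` was tested in a functional assay on PC-3 cells (Homo sapiens) for inhibition, read by sulforhodamine B assay, with a stated time of 48 h (a lower number here means a stronger inhibitor, a higher number a weaker inhibitor), where it gives only a limit of the assay, > 100000 nM, rather than a number. Compound 2 `O=c1c(C2N=C(c3ccccc3)SS2)coc2cc(Cl)ccc12` gives 38400 nM in this assay, the lowest of the two numbers shown; the nearest is compound 3 `O=c1c(C(=S)Nc2ccccc2)coc2cc(Cl)c(Cl)cc12` at 95400 nM. Among the measured compounds shown here, the one measured step, an at least 2.6-fold lower number from compound 1 to compound 2 (0.41 log units; beyond the scatter), was a chloro in place of hydrogen on an aromatic carbon. Compound 4 `O=c1c(C2N=C(c3ccccc3)SS2)coc2cc(Cl)c(Cl)cc12` differs from compound 2 by chloro in place of hydrogen on an aromatic carbon. For the measured compounds named here, that earlier step, whose size rests on the limit (the limit of > 100000 nM in this assay, at which 1 of the 3 values shown sits), is the only guide; a second chloro is expected to give a modest lowering at most, possibly none beyond the scatter. Compound 4 is therefore estimated at 25000 nM, between 9000 nM and 70000 nM, a step of a 1.5-fold lower number from compound 2 to compound 4 (0.19 log units; within the scatter) in this assay.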

Compound 4, half-maximal inhibitory concentration: 60000 nM
Estimate against measurement, compound 4: 2.4-fold (0.38 log units) below, within the range that was stated.
By their numbers in this assay, from the lowest: compounds 2, 4 and 3 (each within the scatter of the next, the first and the last beyond it). At a limit, above all of these: compound 1.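

In this assay, the second chloro, on the aromatic carbon ortho to a chloro group, gives a 1.6-fold higher number from compound 2 to compound 4 (0.19 log units; within the scatter). The earlier chloro step had moved the number beyond the scatter, whereas this one does not, so at this position the added chloro brings no change that can be told from repeated measurement. The earlier step remains only a bound on its size: the limit of > 100000 nM in this assay, at which 1 of the 4 values shown sits.

The compounds shown leave open whether an amine or a methoxy group on this carbon would move the number beyond the scatter. They also leave open what a chloro here would do without the other chloro.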